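The source may report more compounds than this note shows. Statements on the series, on what has been measured and on what is new or still open speak of the compounds shown alone.

Working notes on the series.

Two compounds of this set carry a measurement so far. Among the compounds with values here, compound 1 `O=Cc1ccc(-c2cn3ccnc3c(-c3ccc4ncn(C5CCCCC5)c4c3)n2)cc1` and compound 2 `CCc1ccc(-c2cn3ccnc3c(-c3ccc4ncn(Cc5ccccc5)c4c3)n2)cc1` share a common core and differ in two places at once, so no single step between them is available. In a functional assay on BT-549 cells (Homo sapiens) for inhibition, read by sulforhodamine B assay, with a stated time of 48 h, tested at 10 uM (a higher number here means more inhibition at the concentration tested (going by the name of the read-out), a lower number less inhibition), compound 1 gives 33.8% and compound 2 gives 15.9%. Compound 2 thus stands at the lowest of the two numbers; its nearest neighbour is compound 1, a number higher by a margin that lies beyond the usual scatter.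

Compound 3 `O=Cc1ccc(-c2cn3ccnc3c(-c3ccc4ncn(Cc5ccccc5)c4c3)n2)cc1` is not yet measured. It is reached from compound 2 by one change: formyl in place of ethyl on an aromatic carbon. The measured pair differs in two places. The effect of this single change on its own has not been isolated. What is available is that compound 1, which carries formyl, gives 33.8% in this assay, while compound 2, which carries ethyl, gives 15.9%.

On that basis an upward step is expected for the change from compound 2 to compound 3, of about a number 12.1 percentage points higher from compound 2 to compound 3 (beyond the scatter), though its size is uncertain. Compound 3 is therefore estimated to give 28% in this assay, within a range of 12% to 45%.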

Compound 3, a percentage reported as inhibition, at one concentration (the size of the read-out at that concentration, not a potency): 33.8%
For compound 3 the middle estimate is 5.8 percentage points below the measured one; the range from low to high includes it.
By their numbers in this assay, from the lowest: compound 2; then compounds 1 and 3 (each within the scatter of the next).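

The change from 4-ethylphenyl to 4-formylphenyl, on an aromatic carbon para to a large group, can now be read on its own: with benzyl held constant on the aromatic nitrogen, this assay gives a number 17.9 percentage points higher from compound 2 to compound 3 (beyond the scatter) for formyl in place of ethyl. Within the data shown here, the group on the aromatic nitrogen can also be read on its own for the first time: with formyl held constant, benzyl in place of cyclohexyl gives no change at the digits printed from compound 1 to compound 3 (within the scatter) in the same assay. The aromatic carbon therefore responds to this change with benzyl present, whereas, with formyl present, this read-out does not separate benzyl from cyclohexyl at the single concentration tested.

As far as these compounds go, it remains open whether ethyl and formyl would differ to the same extent with cyclohexyl on the nitrogen, and whether benzyl and cyclohexyl would still match with ethyl on the aromatic ring. Also open, from the compounds shown here alone, is how a carboxylic acid, an amine or a longer chain at the same aromatic carbon would compare with formyl in this cell line.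

No independent measurement bears on why the formyl-for-ethyl step arises.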